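Methyl for Bromine on a Limit-Bound Imine

A few compounds are considered here, and "the series" means these few. Any claim that something is new, unique, unknown or untested is made for them only; others in the source may bear on it.

Compound 1 `Oc1cccc(/C=N/c2ccc(OCc3ccccc3)cc2)c1O` gives 13300 nM in a functional assay, with a stated time of 30 min; a lower number here means a stronger inhibitor, a higher number a weaker inhibitor.
Compound 2 `Cc1ccc(/C=N/c2ccc(OCc3ccccc3)cc2)c(O)c1` gives > 200000 nM in this assay, which is a limit of the assay and not a number.
Compound 3 `Oc1ccc(Br)cc1/C=N/c1ccc(OCc2ccccc2)cc1` gives > 200000 nM in this assay, again a limit of the assay and not a number.

Compound 3 therefore stands at the edge of what this assay can report: the limit of > 200000 nM in this assay, at which 2 of the 3 values shown sit. Compound 4 `Cc1ccc(O)c(/C=N/c2ccc(OCc3ccccc3)cc2)c1` differs from compound 3 in one place, (methyl in place of bromo on an aromatic carbon). Among the compounds with values here, two measured steps bear on this change. Both an at least 15-fold higher number from compound 1 to compound 2 (1.17 log units; beyond the scatter) and an at least 15-fold higher number from compound 1 to compound 3 (1.17 log units; beyond the scatter) are large, each running from a readable number into the limit, while a step that the two limits leave unreadable from compound 2 to compound 3 cannot be read, since both of its compounds sit at the limit. Compound 2 already carries a methyl on its 2-hydroxy-4-methylphenyl group and reaches no number; compound 4 carries a methyl on a 2-hydroxy-5-methylphenyl group. Compound 4 is thus expected to stay where compound 3 stands, and a number no higher from compound 3 to compound 4 (the limit leaves the size open) is expected to be no step beyond the scatter, in no clear direction. For compound 4 the estimated value is 200000 nM, with an expected range from 50000 nM to 600000 nM, most likely reported only as a limit.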

Compound 4, half-maximal inhibitory concentration: > 200000 nM
Compound 4 ended at the assay's limit (the forecaster's own chance of this, stated with the estimate: 75%); the middle value lies on the limit itself.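

In this assay, methyl in place of bromo at this place, para to a hydroxy group, does not bring the compound off the assay's limit, so neither group gives a readable number here. The one step that can be read, an at least 15-fold higher number from compound 1 to compound 4 (1.17 log units; beyond the scatter), is large, like the two earlier steps from compound 1, so the 2-hydroxy-5-methylphenyl group joins the 2-hydroxy-4-methylphenyl and 5-bromo-2-hydroxyphenyl groups in losing the readable number of compound 1, whose 2,3-dihydroxyphenyl group remains the only one shown with a number. The steps among compound 2, compound 3 and compound 4 cannot be read, since both ends of each sit at a limit and no order among these compounds can be given: the limit of > 200000 nM in this assay, at which 3 of the 4 values shown sit.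

As far as these compounds go, whether an amine or a carboxylic acid at this same place, para to the hydroxy group, would bring back a readable number stays open. Also open, from the compounds shown here alone, is whether compound 1 would keep its number if a bromo or methyl group were added to its 2,3-dihydroxyphenyl group.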